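From Methoxy to Propoxy: What to Expect for Compound 3

The source may report more compounds than this note shows. Statements on the series, on what has been measured and on what is new or still open speak of the compounds shown alone.

Measured so far:
Compound 1 `COc1ccc(S(=O)(=O)NC(=O)Nc2ccc(Cl)cc2)s1`: 100%
Compound 2 `CCCc1ccc(S(=O)(=O)NC(=O)Nc2ccc(Cl)cc2)s1`: 39%

Two compounds share a common core and differ only in one group on an aromatic carbon. In a functional assay on the whole organism (6C3HED cells, Mus musculus) for inhibition, at a dose of 300 mg/kg by the oral route (on this read-out higher numbers stand for more inhibition at the one dose given (going by the name of the read-out) and lower numbers for less inhibition), compound 1 gives 100%, the highest of the two numbers. Compound 2 carries propyl in place of methoxy, and in this assay compound 2 gives 39%. Within the data shown here, the step of a number 61 percentage points lower from compound 1 to compound 2 (beyond the scatter) is the only measured step available, and it is large.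

The unmeasured compound 3 `CCCOc1ccc(S(=O)(=O)NC(=O)Nc2ccc(Cl)cc2)s1` differs from compound 1 as follows: ethyl in place of hydrogen on a saturated chain carbon bound to an oxygen on an aromatic ring. Read one bond further out, methoxy becomes propoxy. The measured step from compound 1 to compound 2 bears on this only partly, because a number 61 percentage points lower from compound 1 to compound 2 (beyond the scatter) describes a change that removes the oxygen entirely, while compound 3 keeps it and only lengthens the chain. A drop is therefore plausible, but a smaller one than that step. The expected step is a number 30 percentage points lower from compound 1 to compound 3 (beyond the scatter). For compound 3 the estimate in this assay is 70%, with a range from 35% to 100%.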

Compound 3, a percentage reported as inhibition, in the whole organism at one dose (the size of the read-out at that dose, not a potency): 63%
Estimate against measurement, compound 3: 7 percentage points above; the measured number falls inside the stated range.
By their numbers in this assay, from the lowest: compound 2; then compound 3; then compound 1.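

Compound 2 changed the oxygen and the chain in one step, so it could not show which change counted; compound 3 separates them. In this assay, keeping the oxygen and going from methoxy to propoxy gives a number 37 percentage points lower from compound 1 to compound 3 (beyond the scatter), so lengthening the chain on that oxygen is enough on its own to lower the number, even with the oxygen still in place. With the chain length kept, propoxy in place of propyl on an aromatic carbon gives a number 24 percentage points higher from compound 2 to compound 3 (beyond the scatter), so the oxygen also makes a difference that goes beyond the scatter, and the large fall seen with compound 2 is best read as the sum of two separate changes rather than the loss of the oxygen alone.

The data offer no measurement that would explain why either change moves the number in this assay. Still open, as far as these compounds go, is how ethoxy or the longer butoxy chain would fall along this series, and whether an amine on the same aromatic carbon would keep the number as high as methoxy does in compound 1.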